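The compounds below may be only part of what the source reports. "The series", "measured", "known", "first", "only" and "open" are said of these compounds alone.

Measured in an assay on MDA-MB-231 cells for binding affinity to C-X-C chemokine receptor type 4 (Homo sapiens), read by microscopy, with stated times of 10 min and 30 min; on this read-out lower numbers stand for an effect already at smaller amounts and higher numbers for an effect only at larger amounts of compound:
compound 1 `O=C(NCc1ccc(CNS(=O)(=O)c2ccc(Cl)cc2)cc1)c1ccc(CNc2ncccn2)cc1` gives 100 nM
compound 2 `O=C(NCc1ccc(CNS(=O)(=O)c2ccccc2)cc1)c1ccc(CNc2ncccn2)cc1` gives 1 nM

Among the compounds with values here, compound 2 holds the lowest of these two numbers, and the only measured step, a 100-fold lower number from compound 1 to compound 2 (2.00 log units; beyond the scatter), separates it from compound 1. Compound 3 `O=C(NCc1ccc(CNS(=O)(=O)c2ccc(-c3ccc(F)cc3)cc2)cc1)c1ccc(CNc2ncccn2)cc1` differs from compound 2 by 4-fluorophenyl in place of hydrogen on an aromatic carbon. That single step bears on this change, since it too concerns a group on an aromatic carbon, and it was large. A step upward in this assay is therefore expected for compound 3, though with one step only its size is uncertain, estimated as a 30-fold higher number from compound 2 to compound 3 (1.48 log units; beyond the scatter). Compound 3 is expected to give 30 nM, within a range of 3 nM to 300 nM.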

Compound 3, effective concentration (reported as EC, without a stated level of effect): 1000 nM
Compound 3: middle estimate off by 33-fold (1.52 log units), on the low side, and the stated range ends below it.
By their numbers in this assay, from the lowest: compound 2; then compound 1; then compound 3.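

At this position, 4-fluorophenyl is tolerated even less than chloro: the change gives a 1000-fold higher number from compound 2 to compound 3 (3.00 log units; beyond the scatter) when it replaces hydrogen, and a 10-fold higher number from compound 1 to compound 3 (1.00 log units; beyond the scatter) when it replaces chloro. In this assay the numbers therefore rise in the order hydrogen, chloro, 4-fluorophenyl, so both substituents shown give higher numbers than hydrogen. Nothing available explains this order.

As far as these compounds go, whether a methyl, a methoxy, an amine or a carboxylic acid on this aromatic carbon would keep the number near that of compound 2 stays open. So does whether fluoro would behave like chloro.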